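Working notes: from compound 3 to compound 4

This account rests on a few compounds, and the source may have more. Where it says the series, first, only, none or still open, it means among the compounds named here.

In a functional assay on B16 cells (Mus musculus) for inhibition (a lower number here means a stronger inhibitor, a higher number a weaker inhibitor), compound 1 `COc1ccc(/C=C/C(=O)OCc2cc(=O)oc3cc(OC)c(OC)cc23)cc1` gives 0.96 ug/mL. Compound 2 `COc1cc2oc(=O)cc(COC(=O)/C=C/c3ccc(Cl)cc3)c2cc1OC` is reported as a limit, > 10 ug/mL. Compound 3 `COc1cc2oc(=O)cc(COC(=O)/C=C/c3ccc(O)cc3)c2cc1OC` gives 4.15 ug/mL, the higher of the two actual numbers, and compound 1 holds the nearest one.

Compound 4 `COc1ccc(/C=C/C(=O)OCc2cc(=O)oc3cc(OC)c(OC)cc23)cc1O` differs from compound 3 on a double-bonded chain carbon bound to a double-bonded chain carbon: 3-hydroxy-4-methoxyphenyl in place of 4-hydroxyphenyl on a double-bonded chain carbon bound to a double-bonded chain carbon. Compound 4 shares with compound 1 a methoxy on the phenyl group, which compound 3 lacks, while also keeping a hydroxy. Among the compounds with values here, no measured compound carries both groups.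

The most relevant measured comparison is a 4.3-fold higher number from compound 1 to compound 3 (0.64 log units; beyond the scatter), a modest step. The changes involving chloro, an at least 10-fold higher number from compound 1 to compound 2 (1.01 log units; beyond the scatter) and an at least 2.4-fold lower number from compound 2 to compound 3 (0.38 log units; beyond the scatter), show that the number also responds to other groups on this phenyl ring.

A modest fall is therefore expected, with the expected step being a 2.3-fold lower number from compound 3 to compound 4 (0.36 log units; beyond the scatter). For compound 4 the estimated value is 1.8 ug/mL, with an expected range of 0.6 ug/mL to 6 ug/mL.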

Compound 4, half-maximal inhibitory concentration: 3 ug/mL
The estimate for compound 4 lay 1.7-fold (0.22 log units) below the measured number; measured number inside the range.
By their numbers in this assay, from the lowest: compound 1; then compounds 4 and 3 (each within the scatter of the next). At a limit, above all of these: compound 2.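

In this assay, adding a hydroxy to the phenyl group of compound 1 gives a 3.1-fold higher number from compound 1 to compound 4 (0.49 log units; beyond the scatter), so the methoxy-bearing ring does not tolerate this extra group without loss. Going the other way, 3-hydroxy-4-methoxyphenyl in place of 4-hydroxyphenyl gives a 1.4-fold lower number from compound 3 to compound 4 (0.14 log units; within the scatter): the methoxy does not restore the number of compound 1 while a hydroxy remains, and both hydroxy compounds, compound 3 and compound 4, stay weaker than compound 1. The step of an at least 3.3-fold lower number from compound 2 to compound 4 (0.52 log units; beyond the scatter) is only a floor, as compound 2 is a limit and not a number: the limit of > 10 ug/mL in this assay, at which 1 of the 4 values shown sits.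

On these data alone, it remains open whether the higher number of compound 4 belongs to the hydroxy as such or to its place on the ring. Also open, as far as these compounds go, is how an amine or a fluoro on the phenyl group, or a longer chain in place of the methoxy, would compare with compound 1.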